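This account rests on a few compounds, and the source may have more. Where it says the series, first, only, none or still open, it means among the compounds named here.

Compound 1 `Cc1c(Cn2ccnc2)n(CCNS(=O)(=O)c2ccc(F)cc2)c2ccc(CCC(=O)O)cc12` was tested in an assay with Thromboxane-A synthase (Homo sapiens) as the target, using microsomes (on this read-out higher numbers stand for weaker inhibition and lower numbers for stronger inhibition), where compound 1 gives 135 nM. Among the three compounds measured so far, compound 1 holds the highest number. Compound 3 `Cc1c(Cc2cccnc2)c2cc(CCC(=O)O)ccc2n1CCNS(=O)(=O)c1ccc(F)cc1` gives 61 nM in this assay, a lower number than compound 1 by a margin beyond the usual scatter. Compound 2 `Cc1[nH]c2ccc(CCC(=O)O)cc2c1Cc1ccncc1` gives 22 nM in this assay, the lowest number of the three, again separated from compound 1 by more than the scatter. On these numbers compound 1 is the weakest inhibitor of the three.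

Compound 4 `Cc1c(Cn2ccnc2)n(CCNS(=O)(=O)c2ccc(F)cc2)c2ccc(C(=O)O)cc12` has not yet been measured. It differs from compound 1 in a single place: carboxy in place of 2-carboxyethyl on an aromatic carbon. Among the compounds with values here, all three measured compounds carry the 2-carboxyethyl chain, so nothing measured here shows what shortening it to carboxy does, and no step between measured compounds covers this change. The expectation therefore rests on compound 1 alone, which already gives 135 nM as the highest number of the set. The step of a 3.3-fold higher number from compound 1 to compound 4 (0.52 log units; beyond the scatter) is expected to run toward a higher number, that is weaker inhibition, and to exceed the scatter. Compound 4 is estimated to give 450 nM in this assay, within a range from 120 nM to 1700 nM.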

Compound 4, half-maximal inhibitory concentration: 20 nM
The estimate for compound 4 lay 23-fold (1.35 log units) above the measured number, and the stated range ends above it.
By their numbers in this assay, from the lowest: compounds 4 and 2 (each within the scatter of the next); then compound 3; then compound 1.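

In this assay, putting carboxy in place of 2-carboxyethyl on this aromatic carbon gives a 6.8-fold lower number from compound 1 to compound 4 (0.83 log units; beyond the scatter), a change beyond the scatter and toward stronger inhibition. Compounds 1, 2 and 3 all carry the 2-carboxyethyl chain, so they could not show that inhibition at this position responds to the length of the link to the acid; this pair shows that it does, and that the chain is not needed for inhibition in the core of compound 1. The change removes carbon only, from 5 heavy atoms to 3, while the counted hydrogen-bond donor and acceptor stay the same, but no measurement shown here bears on why the shorter group gives the lower number.

The compounds shown leave open whether the same shortening would lower the number for compound 2 or compound 3, since this single step belongs to the core of compound 1. They also leave open how a longer chain ending in a carboxylic acid, a primary amide or an amine would fare on this aromatic carbon.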